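Aryl amide swap on a shared aminopyrimidine core

The source may report more compounds than this note shows. Statements on the series, on what has been measured and on what is new or still open speak of the compounds shown alone.

Measured compounds:
compound 1 `Cc1noc(C)c1-c1cnc(N)c(Oc2ccc(C(=O)Nc3ccc(Cl)cn3)cc2)n1`: 19200 nM
compound 2 `Cn1cc(-c2cnc(N)c(Oc3ccc(C(=O)Nc4ccc(Cl)cc4)cc3)n2)cn1`: 3440 nM
compound 3 `Cn1cc(-c2cnc(N)c(Oc3ccc(C(=O)Nc4cccc(Cl)c4)cc3)n2)cn1`: 4460 nM

In a functional assay on HeLa cells (Homo sapiens) for inhibition, read by MTT assay, with a stated time of 72 h (a higher number here means a weaker inhibitor, a lower number a stronger inhibitor), compound 3 gives 4460 nM, the second highest of the three numbers; compound 2 stands nearest to it, and compound 1 furthest away. Compound 4 `Cn1cc(-c2cnc(N)c(Oc3ccc(C(=O)Nc4ccc(Cl)cn4)cc3)n2)cn1` has not been measured. It differs from compound 3 in one place: 5-chloropyridin-2-yl in place of 3-chlorophenyl on an amide-type nitrogen. Among the measured compounds shown here, only one measured step concerns this amide-type nitrogen, a 1.3-fold higher number from compound 2 to compound 3 (0.11 log units; within the scatter), a move of a chlorine around the same ring and not a ring change. Compound 1 carries the same 5-chloropyridin-2-yl amide but another group on the core, so its value of 19200 nM can only hint that this amide sits on the weaker side. Compound 4 is therefore expected to move a 1.7-fold higher number from compound 3 to compound 4 (0.23 log units; within the scatter) in this assay, with wide uncertainty. Compound 4 is estimated at 7500 nM, within 2500 nM to 22000 nM.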

Compound 4, half-maximal inhibitory concentration: 21500 nM
Estimate against measurement, compound 4: 2.9-fold (0.46 log units) below; low and high end bracket the measured number.
By their numbers in this assay, from the lowest: compounds 2 and 3 (each within the scatter of the next); then compounds 1 and 4 (each within the scatter of the next).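

In this assay the change of ring on the amide-type nitrogen matters more than the earlier chlorine move, which stayed within the scatter: the data show a 4.8-fold higher number from compound 3 to compound 4 (0.68 log units; beyond the scatter) and a 6.3-fold higher number from compound 2 to compound 4 (0.80 log units; beyond the scatter), both beyond it. With 5-chloropyridin-2-yl held fixed, exchanging the group on the core gives a 1.1-fold higher number from compound 1 to compound 4 (0.05 log units; within the scatter), so the two core groups cannot be told apart with this amide. Nothing available accounts for the ring effect. On these data alone, it remains open whether a 5-methoxypyridin-2-yl or a nitrile in place of the chlorine would behave the same way.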